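Ring Size at the Amine Side Chain: Cyclobutyl to Cyclopentyl

This account rests on a few compounds, and the source may have more. Where it says the series, first, only, none or still open, it means among the compounds named here.

Compound 1 `CC(C)(C)OC(=O)CCCN1CCc2c(sc(NC(=O)Nc3ccc(Cl)cc3)c2C(N)=O)C1`: 560 nM
Compound 2 `CC(C)(C)OC(=O)CN1CCc2c(sc(NC(=O)Nc3ccc(Cl)cc3)c2C(N)=O)C1`: > 25000 nM
Compound 3 `NC(=O)c1c(NC(=O)Nc2ccc(Cl)cc2)sc2c1CCN(CC1CCC1)C2`: 1360 nM

Of the compounds shown here, three sharing one core have been measured in a functional assay (strain AB) with Danio rerio as the target, read by microscopy, with a stated time of 1 h; on this read-out higher numbers stand for an effect only at larger amounts of compound and lower numbers for an effect already at smaller amounts. Compound 1 gives 560 nM. For compound 2 the value of > 25000 nM is a limit of this assay and not a number. Compound 3 gives 1360 nM, the higher of the two numbers available, the step being a 2.4-fold higher number from compound 1 to compound 3 (0.39 log units; beyond the scatter); the step of an at least 18-fold lower number from compound 2 to compound 3 (1.26 log units; beyond the scatter) shows the same position tolerates a cyclobutyl far better than a tert-butoxycarbonyl.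

Compound 4 `NC(=O)c1c(NC(=O)Nc2ccc(Cl)cc2)sc2c1CCN(CC1CCCC1)C2` differs from compound 3 in one place: cyclopentyl in place of cyclobutyl on a saturated chain carbon bound to an amine nitrogen in a ring. For the measured compounds named here, no measured step covers a change of ring size at this position; the steps of a 2.4-fold higher number from compound 1 to compound 3 (0.39 log units; beyond the scatter) and an at least 18-fold lower number from compound 2 to compound 3 (1.26 log units; beyond the scatter) only show that a saturated hydrocarbon group there sits between the two earlier outcomes. Compound 4 is therefore expected to stay close to compound 3 in this assay, with an estimated step of a 1.2-fold lower number from compound 3 to compound 4 (0.09 log units; within the scatter), not beyond the scatter. Compound 4 is estimated at 1100 nM, within 400 nM to 3500 nM.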

Compound 4, half-maximal effective concentration: 1830 nM
Compound 4: middle estimate off by 1.7-fold (0.22 log units), on the low side; low and high end bracket the measured number.
By their numbers in this assay, from the lowest: compound 1; then compounds 3 and 4 (each within the scatter of the next). At a limit, above all of these: compound 2.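

In this assay, enlarging the ring from cyclobutyl to cyclopentyl on a saturated chain carbon bound to an amine nitrogen in a ring gives a 1.3-fold higher number from compound 3 to compound 4 (0.13 log units; within the scatter), so at this position the read-out does not separate the two ring sizes. The cyclopentyl group keeps the same standing against both tert-butoxycarbonyl side chains, with an at least 13-fold lower number from compound 2 to compound 4 (1.13 log units; beyond the scatter) on one side and a 3.3-fold higher number from compound 1 to compound 4 (0.51 log units; beyond the scatter) on the other. Compound 2 stands at a limit and not a number: the limit of > 25000 nM in this assay, at which 1 of the 4 values shown sits.

Going by these compounds, whether cyclopropyl or cyclohexyl would fit the same picture stays open, as does what an amine or a carboxylic acid on the side chain would give. The compounds shown also do not separate the share of chain length from that of the tert-butoxycarbonyl end in compound 1.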